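The source may hold more compounds than are shown below. What is called first, only, known or untested is meant among the compounds shown, and "the series" means these compounds.

Of the compounds shown here, three built on one shared core have been measured so far. In an assay on mitochondria from L6 cells (Rattus norvegicus) for activation, with a stated time of 90 min (on this read-out higher numbers stand for an effect only at larger amounts of compound and lower numbers for an effect already at smaller amounts), compound 1 `FC(F)(F)c1ccccc1Nc1nc2nonc2nc1Nc1ccccc1C(F)(F)F` gives 1000 nM and compound 2 `FC(F)(F)c1cccc(Nc2nc3nonc3nc2Nc2cccc(C(F)(F)F)c2)c1` gives 700 nM. Compound 3 `Fc1ccccc1Nc1nc2nonc2nc1Nc1ccccc1` gives 2200 nM, the highest of the three numbers, and its gaps to compound 1 and to compound 2 both lie beyond the scatter. Compound 4 `Cc1ccc(Nc2nc3nonc3nc2Nc2ccccc2F)cc1` differs from compound 3 in one place: methyl in place of hydrogen on an aromatic carbon. Among the compounds with values here, no measured pair shows this change, so its size is uncertain. Compounds 1 and 2, which carry groups on both rings, sit at lower numbers than compound 3, so a modest move toward lower numbers seems more plausible than a rise. The step of a 1.5-fold lower number from compound 3 to compound 4 (0.17 log units; within the scatter) is expected to be small. Compound 4 is expected to give about 1500 nM, within 600 nM to 4000 nM.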

Compound 4, half-maximal effective concentration: 2100 nM
Compound 4: middle estimate off by 1.4-fold (0.15 log units), on the low side; low and high end bracket the measured number.
By their numbers in this assay, from the lowest: compounds 2 and 1 (each within the scatter of the next); then compounds 4 and 3 (each within the scatter of the next).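

Methyl in place of hydrogen, on an aromatic carbon para to a large group, is the first single change that can be read directly, and it gives a 1.0-fold lower number from compound 3 to compound 4 (0.02 log units; within the scatter) in this assay. Compound 3 and compound 4 therefore cannot be told apart, so this position accepts the phenyl to 4-methylphenyl change without a step beyond the scatter. Nothing at hand explains this result. From the compounds shown here alone, whether a longer chain, an amine or a carboxylic acid at this position would also stay within the scatter remains open.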